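This account rests on a few compounds, and the source may have more. Where it says the series, first, only, none or still open, it means among the compounds named here.

In a functional assay on B16-F10 cells (Mus musculus) for antiproliferative activity, read by ELISA and MTT assay, with a stated time of 48 h; a lower number here means a stronger inhibitor, a higher number a weaker inhibitor:
compound 1 `Cc1ccc(S(=O)(=O)NC(=O)/C=C/c2ccccc2)cc1` gives 13.8 ug/mL
compound 2 `O=C(/C=C/c1ccccc1)NS(=O)(=O)c1ccc(Cl)cc1` gives 2.2 ug/mL
compound 3 `O=C(/C=C/c1ccccc1)NS(=O)(=O)c1ccc(Br)cc1` gives 3.9 ug/mL

Compound 3 stands second highest of these three numbers. Its nearest is compound 2, with a 1.8-fold higher number from compound 2 to compound 3 (0.25 log units; within the scatter); its furthest is compound 1, with a 3.5-fold lower number from compound 1 to compound 3 (0.55 log units; beyond the scatter). Compound 4 `COc1ccc(/C=C/C(=O)NS(=O)(=O)c2ccc(Br)cc2)cc1` differs from compound 3 by methoxy in place of hydrogen on an aromatic carbon. Going by the values given here, none of the measured steps bears on this change: a 6.3-fold lower number from compound 1 to compound 2 (0.80 log units; beyond the scatter), a 3.5-fold lower number from compound 1 to compound 3 (0.55 log units; beyond the scatter) and a 1.8-fold higher number from compound 2 to compound 3 (0.25 log units; within the scatter) all exchange one small group for another at a different aromatic carbon from the one altered here, so the data give no direct guide. The expectation for compound 4 is therefore no step beyond the scatter in this assay, that is a 1.0-fold higher number from compound 3 to compound 4 (0.01 log units; within the scatter). Compound 4 is estimated at 4 ug/mL, within a range from 1.5 ug/mL to 11 ug/mL.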

Compound 4, half-maximal inhibitory concentration: 5.8 ug/mL
The estimate for compound 4 lay 1.5-fold (0.16 log units) below the measured number; the measured number falls inside the stated range.
By their numbers in this assay, from the lowest: compounds 2, 3 and 4 (each within the scatter of the next, the first and the last beyond it); then compound 1.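

In this assay, methoxy in place of hydrogen on an aromatic carbon, para to a large group, gives a 1.5-fold higher number from compound 3 to compound 4 (0.17 log units; within the scatter). This is the first change shown on this ring, which carries no substituent in compound 1, compound 2 or compound 3, and here the position takes a methoxy group without a step beyond the scatter. Nothing measured here explains this outcome. As far as these compounds go, whether a hydroxyl group or an amine at this carbon would behave the same stays open, as does whether methoxy would give a similar step on compound 2, which carries chloro instead of bromo.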